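Shortening the sulfur substituent on the cyclic nucleotide core

A few compounds are considered here, and "the series" means these few. Any claim that something is new, unique, unknown or untested is made for them only; others in the source may bear on it.

Measured so far:
compound 1, `Nc1ncnc2c1nc(SCc1ccccc1)n2[C@@H]1O[C@@H]2COP(=O)(O)O[C@H]2[C@H]1O`, 183%
compound 2, `Nc1ncnc2c1nc(N)n2[C@@H]1O[C@@H]2COP(=O)(O)O[C@H]2[C@H]1O`, 663%
compound 3, `[N-]=[N+]=Nc1nc2c(N)ncnc2n1[C@@H]1O[C@@H]2COP(=O)(O)O[C@H]2[C@H]1O`, 594%

In a functional assay on the whole organism for activation, with Mus musculus as the target, with stated times of 14 days and 2 h, at a dose of 15 mg/kg by the intravenous route (a higher number here means a stronger effect of the compound at the dose given, a lower number a weaker effect), compound 1 stands lowest of the three, with compound 3 nearest and compound 2 furthest. Compound 4, `CSc1nc2c(N)ncnc2n1[C@@H]1O[C@@H]2COP(=O)(O)O[C@H]2[C@H]1O`, differs from compound 1 by hydrogen in place of phenyl on a saturated chain carbon bound to a sulfur, so the benzylsulfanyl group becomes methylsulfanyl. The measured steps touch this only indirectly: a number 480 percentage points higher from compound 1 to compound 2 (beyond the scatter) and a number 411 percentage points higher from compound 1 to compound 3 (beyond the scatter) both swap out the whole benzylsulfanyl group and both climb far. Trimming it to methylsulfanyl keeps the sulfur, so compound 4 is expected to gain less than those two. The estimate for compound 4 is 350%, within 150% to 600%, which is expected to be a step of a number 167 percentage points higher from compound 1 to compound 4 (beyond the scatter).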

Compound 4, a percentage reported as activity, at one dose (the size of the read-out at that dose, not a potency): 645%
Beside the measured number, compound 4's estimate is 295 percentage points below it; the whole stated range lies below it.
By their numbers in this assay, from the lowest: compound 1; then compound 3; then compound 4; then compound 2.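

In this assay, removing only the phenyl while keeping the sulfur gives a number 462 percentage points higher from compound 1 to compound 4 (beyond the scatter) and so the low number of compound 1 goes with the phenyl of the benzylsulfanyl group, not with a sulfur at this position. Methylsulfanyl also sits close to the sulfur-free groups, with a number 51 percentage points higher from compound 3 to compound 4 (beyond the scatter) and a number 18 percentage points lower from compound 2 to compound 4 (beyond the scatter) as a modest gap. Nothing available explains why this happens.

Still open, going by these compounds, is how the number responds to an ethylsulfanyl or longer chain on the sulfur. A hydroxyl or methoxy in place of methylsulfanyl would show whether other small groups behave alike.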